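Methyl in place of fluoro, with only limits so far

The source may hold more compounds than are shown below. What is called first, only, known or untested is meant among the compounds shown, and "the series" means these compounds.

Compound 1 `Cc1ccc(-c2nc(CN3CCC(C(=O)NCCCN4C[C@H](C)C[C@H](C)C4)CC3)c(C)o2)cc1` gives > 69 ug/mL (a limit)
Compound 2 `COc1cccc(F)c1-c1nc(CN2CCC(C(=O)NCCCN3C[C@H](C)C[C@H](C)C3)CC2)c(C)o1` gives > 74 ug/mL (a limit)

Both entries come from a physicochemical assay for solubility, in phosphate buffer, measured as kinetic solubility, at pH 7.4 (on this read-out higher numbers stand for higher solubility and lower numbers for lower solubility), and neither is a number. For the measured compounds named here, compound 2 stands only at a limit (> 74 ug/mL), and the single other value, that of compound 1, is a limit as well.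

Compound 3 `COc1cccc(C)c1-c1nc(CN2CCC(C(=O)NCCCN3C[C@H](C)C[C@H](C)C3)CC2)c(C)o1` has not been measured. It keeps the shared core of compound 2 and differs from it as follows: methyl in place of fluoro on an aromatic carbon (methyl in place of fluoro on an aromatic carbon, ortho to a large group and meta to a methoxy group). The same difference can be read as 2-fluoro-6-methoxyphenyl to 2-methoxy-6-methylphenyl.

Going by the values given here, only one measured step bears on this change: a step that the two limits leave unreadable from compound 1 to compound 2 with 2-fluoro-6-methoxyphenyl in place of 4-methylphenyl on an aromatic carbon. It offers no size to carry over, so no direction can be drawn from it, and no shift beyond the usual scatter is expected. The expected step is an at least 1.0-fold lower number from compound 2 to compound 3 (0.00 log units; that floor lies within the scatter) and it is only an estimate. Compound 3 may well be reported as a limit too. For compound 3 the estimated value is 73 ug/mL with an expected range (40 ug/mL to 100 ug/mL).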

Compound 3, solubility: > 73 ug/mL
Compound 3 was reported as a limit; the forecaster's own chance of this, stated with the estimate: 80%; the middle value sits exactly at the limit.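

In this assay, for the compounds shown here, compound 1, compound 2 and compound 3 are all reported only as limits, so no step among them can be read, including methyl in place of fluoro from compound 2 to compound 3. The compounds shown leave open how far each lies past its limit, and whether methyl in place of fluoro shifts the read-out at all.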